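Series notes: pyridin-2-yl in place of methylsulfonyl

The source may hold more compounds than are shown below. What is called first, only, known or untested is meant among the compounds shown, and "the series" means these compounds.

Measured compounds:
Compound 1, `CS(=O)(=O)N1CCN(S(=O)(=O)CCCN2CCC(CNC(=O)c3cccc4c3OCCO4)CC2)CC1`: in an assay on isolated protein for inhibition of 5-hydroxytryptamine receptor 4 (Homo sapiens) (a lower number here means a stronger inhibitor, a higher number a weaker inhibitor), compound 1 gives 0.316 nM.
Compound 2, `CCCS(=O)(=O)N1CCN(S(=O)(=O)CCCN2CCC(CNC(=O)c3cccc4c3OCCO4)CC2)CC1`: compound 2 gives 0.1 nM.
Compound 3, `CCCCN1CCC(CNC(=O)c2cccc3c2OCCO3)CC1`: compound 3 gives 0.794 nM.

Compound 1 stands second highest of the three numbers. Compound 2 lies below it, and the step of a 3.2-fold lower number from compound 1 to compound 2 (0.50 log units; beyond the scatter) is modest but beyond the scatter. Among the measured compounds shown here, compound 3, which lacks the sulfonylpiperazine portion altogether, gives the higher number of the pair with compound 1; no single-point step connects these two.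

Compound 4, `O=C(NCC1CCN(CCCS(=O)(=O)N2CCN(c3ccccn3)CC2)CC1)c1cccc2c1OCCO2`, is compound 1 with pyridin-2-yl in place of methylsulfonyl on an amine nitrogen in a ring. For the measured compounds named here, no measured step alters this position: the one measured step, from compound 1 to compound 2, changes the chain on the distant sulfonyl sulfur and is modest. The series therefore gives no direct guide, only a hint that the group on this nitrogen is tolerated in more than one form. A step within the scatter, or a small rise in the number, is expected for compound 4, as a 1.6-fold higher number from compound 1 to compound 4 (0.20 log units; within the scatter). Compound 4 is estimated at 0.5 nM, within the range 0.15 nM to 1.6 nM.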

Compound 4, inhibition constant: 0.251 nM
Compound 4: middle estimate off by 2.0-fold (0.30 log units), on the high side, within the range that was stated.
By their numbers in this assay, from the lowest: compound 2; then compounds 4 and 1 (each within the scatter of the next); then compound 3.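

In this assay, the amine nitrogen in the ring accepts an aromatic ring as well as a sulfonyl group: pyridin-2-yl in place of methylsulfonyl gives a 1.3-fold lower number from compound 1 to compound 4 (0.10 log units; within the scatter), so in this pair a sulfonyl group at this position is not needed to hold the number. Pyridin-2-yl in place of propylsulfonyl gives a 2.5-fold higher number from compound 2 to compound 4 (0.40 log units; beyond the scatter), a modest step, so the number does respond to the group on this nitrogen. Nothing available for these compounds explains either step.

The compounds shown leave open whether the ring nitrogen of pyridin-2-yl matters, which phenyl or pyrimidin-2-yl on the same nitrogen would test. Also open, on these data alone, is how butylsulfonyl or a longer chain on the sulfonyl group would compare with propylsulfonyl.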